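A few compounds are considered here, and "the series" means these few. Any claim that something is new, unique, unknown or untested is made for them only; others in the source may bear on it.

Measured compounds:
compound 1 `O=C(Nc1cccc(-n2cc(-c3ccncc3)c(-c3cc(O)cc(Cl)c3)n2)c1)Nc1ccc(Cl)c(C(F)(F)F)c1`, -38%
compound 2 `O=C(Nc1cccc(-n2cc(-c3ccncc3)c(-c3cc(O)cc(Cl)c3)n2)c1)Nc1ccc(Cl)c(Cl)c1`, -24%
compound 3 `COc1cc(Cl)cc(-c2nn(-c3cccc(NC(=O)Nc4cc(C(F)(F)F)cc(C(F)(F)F)c4)c3)cc2-c2ccncc2)c1`, -70%

These three compounds share a core and were tested in a functional assay on MDA-MB-231 cells (Homo sapiens) for inhibition, read by sulforhodamine B assay, with a stated time of 48 h, tested at 100 uM; a higher number here means a weaker effect of the compound at the concentration tested, a lower number a stronger effect. Compound 2 gives the highest number of the three, that is the weakest effect; its nearest neighbour is compound 1, and the step of a number 14 percentage points higher from compound 1 to compound 2 (beyond the scatter) is beyond the scatter. Among the compounds with values here, compound 3, which carries a methoxy where compounds 1 and 2 carry a hydroxy, stands far lower, but it also differs from compound 2 in the urea-bound ring, so no single step separates the two.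

The next compound, compound 4 `COc1cc(Cl)cc(-c2nn(-c3cccc(NC(=O)Nc4ccc(Cl)c(Cl)c4)c3)cc2-c2ccncc2)c1`, differs from compound 2 only by methyl in place of hydrogen on an oxygen on an aromatic ring, that is hydroxy to methoxy. Within the data shown here, no measured pair isolates this change, so no step can be carried over directly. The values of compound 2 and compound 3 show that the methoxy compound sits much lower, yet part of that gap may belong to the other change. A modest move toward lower numbers is therefore expected for compound 4, a number 14 percentage points lower from compound 2 to compound 4 (beyond the scatter), with wide uncertainty. The value estimated for compound 4 is -38%, between -70% and -5%.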

Compound 4, a percentage reported as activity, at one concentration (the size of the read-out at that concentration, not a potency): -70%
For compound 4 the middle estimate is 32 percentage points above the measured one, within the range that was stated.
By their numbers in this assay, from the lowest: compounds 3 and 4 (each within the scatter of the next); then compound 1; then compound 2.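

Compounds 2 and 4 differ only at the oxygen on the aromatic ring, so the step of a number 46 percentage points lower from compound 2 to compound 4 (beyond the scatter) in this assay can be assigned to the change from 3-chloro-5-hydroxyphenyl to 3-chloro-5-methoxyphenyl alone, which compound 3 could not show. A single added methyl at this position gives a large step, whereas the step of a number 14 percentage points higher from compound 1 to compound 2 (beyond the scatter) on the urea-bound ring is modest. Nothing measured here explains why the methoxy compound has the stronger effect at this concentration.

Going by these compounds, whether the change has a similar size with the chloro and trifluoromethyl ring of compound 1 remains open. On these data alone, it is also open how this position would respond to a longer chain on the oxygen, such as ethoxy, or to an amine in place of the hydroxy.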